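Swapping the sulfonyl substituent in a rat whole-organism series

This account rests on a few compounds, and the source may have more. Where it says the series, first, only, none or still open, it means among the compounds named here.

Measured compounds:
- compound 1 `CC1(C)C=C(n2ccccc2=O)c2cc(S(=O)(=O)NCc3ccccc3)ccc2O1`: 1320 nM
- compound 2 `CN(C)S(=O)(=O)c1ccc2c(c1)C(n1ccccc1=O)=CC(C)(C)O2`: 95.5 nM

Both compounds were tested in a functional assay with Rattus norvegicus as the target; a higher number here means that more compound is needed for the effect, a lower number that less compound is needed. Compound 2 stands at the lowest number of the two, and its nearest neighbour is compound 1 a 14-fold lower number from compound 1 to compound 2 (1.14 log units; beyond the scatter). That single step is the only one shown, and it arose from the change dimethylamino in place of benzylamino on a sulfonyl sulfur.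

Compound 3 `CC1(C)C=C(n2ccccc2=O)c2cc(S(=O)(=O)Oc3ccccc3)ccc2O1` has not yet been measured. It differs from compound 2 at the same sulfonyl sulfur: phenoxy in place of dimethylamino on a sulfonyl sulfur. In this step a small dimethylamino group leaves and a phenoxy group with a six-membered aromatic ring enters, so the sulfonyl position again carries an aromatic ring, as it did in compound 1.

For the measured compounds named here, the one step that bears on this is the large lowering from compound 1 to compound 2 when the aromatic benzylamino group was removed. Restoring an aromatic group at this position is therefore expected to move the number back upward, though the link through oxygen rather than nitrogen leaves the size uncertain. For compound 3 in this assay the expected value is 800 nM, with a range from 200 nM to 3000 nM, meaning an estimated step of an 8.4-fold higher number from compound 2 to compound 3 (0.92 log units; beyond the scatter).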

Compound 3, half-maximal effective concentration: 13.2 nM
Estimate against measurement, compound 3: 61-fold (1.78 log units) above; the whole stated range lies above it.
By their numbers in this assay, from the lowest: compound 3; then compound 2; then compound 1.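

In this assay, an aromatic ring on the sulfonyl sulfur does not by itself raise the number: swapping dimethylamino for phenoxy gives a 7.2-fold lower number from compound 2 to compound 3 (0.86 log units; beyond the scatter), the opposite direction to what the benzylamino group of compound 1 suggested. Compound 1 and compound 3 both carry an aromatic ring at this place, yet they sit at the two ends of the series, with a 100-fold lower number from compound 1 to compound 3 (2.00 log units; beyond the scatter), while compound 2, which has no ring there, falls between them, so the mere presence of a ring does not track the number in these compounds; what differs between the two ring-bearing groups is how the ring is joined to the sulfur. Nothing measured here speaks to the reason for these differences.

From the compounds shown here alone, it remains open whether a phenylamino group, with the ring joined through nitrogen alone, would behave more like the benzylamino group or more like the phenoxy group. Going by these compounds, it is equally open whether a methoxy group on the same sulfur, with the oxygen kept and the ring gone, would hold the low number of compound 3.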